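This account rests on a few compounds, and the source may have more. Where it says the series, first, only, none or still open, it means among the compounds named here.

Measured in a physicochemical assay for acid dissociation:
- Compound 1 `CO[C@@H]1[C@@H](OC(=O)c2ccc(C)[nH]2)[C@@H](O)[C@H](Oc2ccc3c(N4CCN(c5ccccn5)CC4)cc(=O)oc3c2C)OC1(C)C`: 5.5
- Compound 2 `CCN1CCN(c2cc(=O)oc3c(C)c(O[C@@H]4OC(C)(C)[C@H](OC)[C@@H](OC(=O)c5ccc(C)[nH]5)[C@H]4O)ccc23)CC1`: 7.5

Compound 2 stands highest of the two, at 7.5. For the measured compounds named here, the single measured step is large, a number 2.00 log units higher from compound 1 to compound 2 (beyond the scatter), with ethyl in place of pyridin-2-yl on an amine nitrogen in a ring. Compound 3 `CO[C@@H]1[C@@H](OC(=O)c2ccc(C)[nH]2)[C@@H](O)[C@H](Oc2ccc3c(N(C)CCN(C)C)cc(=O)oc3c2C)OC1(C)C` differs from compound 2 on an aromatic carbon: (2-(dimethylamino)ethyl)(methyl)amino in place of 4-ethylpiperazin-1-yl on an aromatic carbon. Going by the values given here, no measured step removes that ring, so the earlier step shows only that changes around this amine can matter. A smaller upward move is expected: a number 0.90 log units higher from compound 2 to compound 3 (beyond the scatter). The estimated value for compound 3 is 8.4, with a range of 7.7 to 9.1.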

Compound 3, acid dissociation constant: 8.2
The estimate for compound 3 lay 0.20 log units above the measured number, within the range that was stated.
By their numbers in this assay, from the lowest: compound 1; then compound 2; then compound 3.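

Putting the open chain (2-(dimethylamino)ethyl)(methyl)amino in place of 4-ethylpiperazin-1-yl on this aromatic carbon gives a number 0.70 log units higher from compound 2 to compound 3 (beyond the scatter) in this assay. The number therefore moves when the piperazine ring itself goes, not only when the group on its nitrogen changes. Set against 4-(pyridin-2-yl)piperazin-1-yl, the same chain gives a number 2.70 log units higher from compound 1 to compound 3 (beyond the scatter), the widest gap among the three compounds. Nothing available explains these shifts. Still open, from the compounds shown here alone, is how a longer chain between the two nitrogens, or a morpholin-4-yl group on this carbon, would read in this assay.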